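The source may report more compounds than this note shows. Statements on the series, on what has been measured and on what is new or still open speak of the compounds shown alone.

Working notes on the series. The shared core of compound 1 `CC(C)=CCOc1ccccc1C1CC(=O)c2ccccc2O1` is kept throughout; the compounds differ only in the group on a saturated chain carbon bound to an oxygen on an aromatic ring. In a functional assay on J774.A1 cells (Mus musculus) for inhibition, read by Griess assay, with stated times of 1 h and 24 h (on this read-out lower numbers stand for stronger inhibition and higher numbers for weaker inhibition), compound 1 gives 34300 nM. Compound 2 `COCOc1ccccc1C1CC(=O)c2ccccc2O1` gives 35200 nM in this assay, and compound 3 `CCCOc1ccccc1C1CC(=O)c2ccccc2O1` gives 44600 nM. On these numbers compound 1 sits at the low end, but the steps are small: a 1.0-fold higher number from compound 1 to compound 2 (0.01 log units; within the scatter) and a 1.3-fold higher number from compound 1 to compound 3 (0.11 log units; within the scatter), while a 1.3-fold higher number from compound 2 to compound 3 (0.10 log units; within the scatter).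

Compound 4 `CC(C)CCOc1ccccc1C1CC(=O)c2ccccc2O1` has not yet been measured in this assay. Relative to compound 1 the change is isobutyl in place of 2-methylprop-1-en-1-yl on a saturated chain carbon bound to an oxygen on an aromatic ring. All three measured steps alter the same position, each exchanging one four-carbon or smaller group for another, and none of them moves the number beyond the scatter. Going by the values given here, the change to compound 4 is of the same kind, and the loss of the double bond outside aromatic rings has no measured counterpart. No step beyond the scatter is therefore expected; the estimate for compound 4 is 38000 nM, with a range from 20000 nM to 72000 nM, which means an expected 1.1-fold higher number from compound 1 to compound 4 (0.04 log units; within the scatter).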

Compound 4, half-maximal inhibitory concentration: 42600 nM
Compound 4: middle estimate off by 1.1-fold (0.05 log units), on the low side; the measured number falls inside the stated range.
By their numbers in this assay, from the lowest: compounds 1, 2, 4 and 3 (each within the scatter of the next).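

Taking out the double bond outside aromatic rings, a change with no measured counterpart among the earlier compounds, leaves the number in this assay within the scatter (a 1.2-fold higher number from compound 1 to compound 4 (0.09 log units; within the scatter)). The first change further out along the chain, isopropyl in place of methyl on a saturated chain carbon, two bonds along the chain from an oxygen on an aromatic ring, also stays within the scatter (a 1.0-fold lower number from compound 3 to compound 4 (0.02 log units; within the scatter)), as does the step that starts from the methoxy group (a 1.2-fold higher number from compound 2 to compound 4 (0.08 log units; within the scatter)). Among these four compounds, no exchange at this position gives a step beyond the scatter, and none goes against that reading, but no measurement is available here to explain the flat response.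

Going by these compounds, it remains open whether an amine, a carboxylic acid or a much longer chain at this place would give a step beyond the scatter. On these data alone, it also remains open whether a phenyl ring on the chain would do so, or whether the chain would matter more with a change elsewhere on the shared core.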